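The compounds below may be only part of what the source reports. "The series", "measured", "known", "first", "only" and "open" are said of these compounds alone.

Three compounds of a shared core were measured in an assay on COS-7 cells for inhibition of patatin-like phospholipase domain-containing protein 2 (Mus musculus), tested at 200 uM; on this read-out lower numbers stand for less inhibition and higher numbers for more inhibition at the one concentration tested (going by the name of the read-out). Compound 1 `CCOC(=O)c1cc(-c2ccc(OCC)cc2)ccn1` gives 72%, compound 2 `CCOC(=O)c1cccc(-c2ccc(OCC)cc2)n1` gives 79%, and compound 3 `CCOC(=O)c1cccc(-c2ccc(OCC)cc2)c1` gives 87%. Compound 3 thus gives the highest of the three numbers, but compound 2 lies within the scatter of it; only compound 1 lies beyond the scatter below compound 3. Compound 4 `CCOC(=O)c1cccc(-c2ccc(CN(C)C)cc2)c1` has not been measured. It differs from compound 3 in one place: (dimethylamino)methyl in place of ethoxy on an aromatic carbon. Among the measured compounds shown here, no measured pair shows this change, so nothing can be said about its size from the data. In this assay the step from compound 3 to compound 4 is expected to be small, downward if anything, and estimated at a number 17 percentage points lower from compound 3 to compound 4 (beyond the scatter). Compound 4 is therefore expected to give 70%, with a range from 45% to 90%.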

Compound 4, a percentage reported as inhibition, at one concentration (the size of the read-out at that concentration, not a potency): 67%
Estimate against measurement, compound 4: 3 percentage points above; the range from low to high includes it.
By their numbers in this assay, from the lowest: compounds 4, 1, 2 and 3 (each within the scatter of the next, the first and the last beyond it).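

Among the compounds shown here, this is the first step at the aromatic carbon para to a large group, and it shows that the read-out responds to what this carbon carries: in this assay, (dimethylamino)methyl in place of ethoxy gives a number 20 percentage points lower from compound 3 to compound 4 (beyond the scatter). The change does not abolish inhibition, as compound 4 still gives 67% at the one concentration tested. No evidence is available that accounts for this step.

As far as these compounds go, how a methoxy, a dimethylamino or a carboxylic acid group would read on this carbon remains open. So does whether (dimethylamino)methyl would give a similar step on the cores of compound 1 and compound 2.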